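Fluoro for acetyl at the assay limit

This account rests on a few compounds, and the source may have more. Where it says the series, first, only, none or still open, it means among the compounds named here.

In a functional assay on AGS cells (Homo sapiens) for inhibition, read by reporter gene assay (on this read-out higher numbers stand for weaker inhibition and lower numbers for stronger inhibition), compound 3 (`CC(=O)c1ccc(OCC(=O)Nc2cccc(C(=O)O)c2)cc1`) gives > 30000 nM as a limit of the assay, not a number. Compound 1 (`Cc1ccc(OCC(=O)Nc2cccc(C(=O)O)c2)cc1`) gives > 30000 nM as a limit too. Compound 2 (`CC(C)(C)c1ccc(OCC(=O)Nc2cccc(C(=O)O)c2)cc1`) gives a true number of 9500 nM and so stands apart, with the limit of > 30000 nM in this assay, at which 2 of the 3 values shown sit, for the other two.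

Compound 4 (`O=C(COc1ccc(F)cc1)Nc1cccc(C(=O)O)c1`) brings fluoro in place of acetyl on an aromatic carbon and has fluoro in place of acetyl on an aromatic carbon. The measured steps that bear on it are an at least 3.1-fold lower number from compound 1 to compound 2 (0.49 log units; beyond the scatter) and an at least 3.1-fold higher number from compound 2 to compound 3 (0.49 log units; beyond the scatter) and a step that the two limits leave unreadable from compound 1 to compound 3, and only tert-butyl gave a reading. No step beyond the scatter is therefore expected, an estimated a number no higher from compound 3 to compound 4 (the limit leaves the size open) in this assay at most near the limit. Compound 4 is expected at about 30000 nM with 12000 nM to 60000 nM as its estimated range.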

Compound 4, half-maximal inhibitory concentration: > 30000 nM
Compound 4: a limit, no number; the forecaster's own chance of this, stated with the estimate: 70%; the middle value lies on the limit itself.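

Swapping tert-butyl for fluoro in this assay gives an at least 3.1-fold higher number from compound 2 to compound 4 (0.49 log units; beyond the scatter), so fluoro, the smallest of these groups by heavy-atom count, does not keep the reading that tert-butyl gave. Of the four groups at this place, tert-butyl alone gives a true number. The steps among compound 1, compound 3 and compound 4 cannot be read, and each of their values is a limit: the limit of > 30000 nM in this assay, at which 3 of the 4 values shown sit.

Going by these compounds, how these three compounds rank against each other stays open. So does whether another group at this place, such as isopropyl, cyclohexyl or trifluoromethyl, would give a true number as tert-butyl does.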